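The compounds below may be only part of what the source reports. "The series", "measured", "known", "first", "only" and "open" are said of these compounds alone.

Compound 2 `CC(C)c1ccc2c(CCCCCS(=O)(=O)Nc3ccccc3)cc(C(=O)O)c-2cc1` is the point of departure. In a functional assay on thoracic aorta for antagonist activity at thromboxane A2 receptor (Rattus norvegicus) (a higher number here means a weaker inhibitor, a lower number a stronger inhibitor), compound 2 gives 1500 nM, the lowest of the two numbers reported, yet its nearest neighbour sits within reach: compound 3 `CC(C)c1ccc2c(CCCCCS(=O)(=O)Nc3ccc(Cl)cc3)cc(C(=O)O)c-2cc1` in this assay gives 1700 nM, and a 1.1-fold higher number from compound 2 to compound 3 (0.05 log units; within the scatter), so the pair cannot be separated. Compound 1 `CC(C)c1ccc2c(CCC/C=N/NC(=O)Nc3ccc(Cl)cc3)cc(C(=O)O)c-2cc1` carries a different linker to the aryl group; in this assay compound 1 gives > 100000 nM, which is a limit of the assay rather than a number (the limit of > 100000 nM in this assay, at which 1 of the 3 values shown sits).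

Compound 4 `CC(C)c1ccc2c(CCCCCS(=O)(=O)Nc3ccccc3)cc(S(=O)(=O)O)c-2cc1` alters the acidic group on the shared core: sulfo in place of carboxy on an aromatic carbon. For the measured compounds named here, none of the measured steps touches this position. The step of a 1.1-fold higher number from compound 2 to compound 3 (0.05 log units; within the scatter) concerns a chloro substitution on the aryl ring, and compound 1 differs in its linker, so the measured compounds give no size for the exchange of the acid. A modest weakening is therefore expected, a 2.7-fold higher number from compound 2 to compound 4 (0.43 log units; beyond the scatter), with wide uncertainty. Compound 4 is estimated to give 4000 nM, expected to fall between 800 nM and 30000 nM.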

Compound 4, half-maximal inhibitory concentration: 1400 nM
Estimate against measurement, compound 4: 2.9-fold (0.46 log units) above; the measured number falls inside the stated range.
By their numbers in this assay, from the lowest: compounds 4, 2 and 3 (each within the scatter of the next). At a limit, above all of these: compound 1.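

In this assay, for the compounds shown here, sulfo in place of carboxy on the aromatic carbon of the five-membered ring gives a 1.1-fold lower number from compound 2 to compound 4 (0.03 log units; within the scatter), the first measured step at this position. With the rest of the structure unchanged, the position therefore accepts sulfo, which brings more heavy atoms and more hydrogen-bond acceptors than carboxy, and the two compounds cannot be separated in this read-out. The data shown offer no explanation for this result.

Going by these compounds, it remains open whether an amide, a tetrazole or a plain hydrogen on this carbon would give a similar number. On these data alone, it is equally open whether sulfo in place of carboxy would give the same result with the chloro-bearing aryl group of compound 3 or with a shorter chain.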